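From fluoro to nitro: an expectation for compound 3

The source may hold more compounds than are shown below. What is called first, only, known or untested is meant among the compounds shown, and "the series" means these compounds.

Two compounds share a core and differ only in the group on the outer aromatic ring. Compound 1 `COc1ccc(Nc2cccc3c2N(S(=O)(=O)c2ccc(OC)cc2)CC3)cc1` carries a methoxy there, and in a functional assay on KB cells (Homo sapiens) for antiproliferative activity (on this read-out lower numbers stand for stronger inhibition and higher numbers for weaker inhibition), compound 1 gives 1200 nM. Compound 2 `COc1ccc(S(=O)(=O)N2CCc3cccc(Nc4ccc(F)cc4)c32)cc1` carries a fluoro instead, and in this assay compound 2 gives 557 nM. Among the measured compounds shown here, the one measured step, a 2.2-fold lower number from compound 1 to compound 2 (0.33 log units; beyond the scatter), is modest but beyond the scatter, and it leaves compound 2 with the lowest of the two numbers.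

Compound 3 `COc1ccc(S(=O)(=O)N2CCc3cccc(Nc4ccc([N+](=O)[O-])cc4)c32)cc1` continues at the same position: nitro in place of fluoro on an aromatic carbon. For the measured compounds named here, no measured step involves a nitro group, so the only guide is that a change at this position between compound 1 and compound 2 moved the number by a modest amount. A step of similar size in either direction, or none beyond the scatter, is therefore the reasonable expectation in this assay, with no basis for choosing a direction.

Compound 3 is accordingly expected to give about 550 nM in this assay, with a range from 150 nM to 2000 nM, which means an expected step of a 1.0-fold lower number from compound 2 to compound 3 (0.01 log units; within the scatter).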

Compound 3, half-maximal inhibitory concentration: 101 nM
Estimate against measurement, compound 3: 5.4-fold (0.74 log units) above, and the stated range ends above it.
By their numbers in this assay, from the lowest: compound 3; then compound 2; then compound 1.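

This position on the outer aromatic ring turns out to be more sensitive than the first pair suggested: in this assay, the change from fluoro to nitro gives a 5.5-fold lower number from compound 2 to compound 3 (0.74 log units; beyond the scatter), a bigger step than the change from methoxy to fluoro, which gave a 2.2-fold lower number from compound 1 to compound 2 (0.33 log units; beyond the scatter). Taken end to end, the exchange of methoxy for nitro gives a 12-fold lower number from compound 1 to compound 3 (1.07 log units; beyond the scatter), so a single group at this one place can shift the number by a large amount while the shared core stays the same. Nothing available here explains why the nitro compound gives the lowest number, so neither the extra heavy atoms nor the hydrogen-bond acceptors that nitro brings can be singled out as the reason.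

The three compounds leave open whether this low number is particular to nitro or is shared by other groups in the same place, such as a nitrile, a carboxylic acid or an amine. They also leave open whether the same exchange of fluoro for nitro would give a step of similar size with a different group on the sulfonyl side of the shared core.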